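This account rests on a few compounds, and the source may have more. Where it says the series, first, only, none or still open, it means among the compounds named here.

Measured so far in a functional assay on NPC-TW01 cells (Homo sapiens) for inhibition, read by MTT assay, with a stated time of 72 h; a lower number here means a stronger inhibitor of growth, a higher number a weaker inhibitor of growth:
compound 1, `COC(=O)c1nc(C2CCCC2)n(-c2ccc(F)cc2)n1`: 10400 nM
compound 2, `COC(=O)c1nc(-c2ccccc2)n(-c2ccc(F)cc2)n1`: 15600 nM
compound 3, `COC(=O)c1nc(C2CCCC2)n(-c2ccc(C(F)(F)F)cc2)n1`: 56400 nM

Compound 3 gives the highest number of the three. Compound 2 sits nearest to it, compound 1 furthest, and the gap from compound 3 to each of them lies beyond the scatter, so compound 3 is the weakest inhibitor of growth among the measured set.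

Compound 4, `COC(=O)c1nc(-c2ccc[nH]2)n(-c2ccc(C(F)(F)F)cc2)n1`, has yet to be measured in this assay. Against compound 3 it shows (1H-pyrrol-2-yl in place of cyclopentyl on an aromatic carbon). Among the compounds with values here, one measured step bears on this: the replacement of cyclopentyl by phenyl at the same position, a 1.5-fold higher number from compound 1 to compound 2 (0.18 log units; within the scatter), which stays within the scatter. From the compounds shown here alone, that step swaps a saturated carbon ring for an aromatic one without a hetero atom or a hydrogen-bond donor, so the nitrogen and the donor that 1H-pyrrol-2-yl brings are untested here. The step of a 5.4-fold higher number from compound 1 to compound 3 (0.73 log units; beyond the scatter) concerns the other aryl group and does not bear on this change.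

On that basis a small step is expected for compound 4 in this assay, a 1.1-fold higher number from compound 3 to compound 4 (0.03 log units; within the scatter), with no clear direction beyond the scatter. The estimate for compound 4 is 60000 nM, expected to fall between 20000 nM and 180000 nM.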

Compound 4, concentration for 50% growth inhibition: > 100000 nM
Compound 4 ended at the assay's limit; the forecaster's own chance of this, stated with the estimate: 25%; middle value at least 1.6-fold (0.22 log units) from the limit.
By their numbers in this assay, from the lowest: compounds 1 and 2 (each within the scatter of the next); then compound 3. At a limit, above all of these: compound 4.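

In this assay compound 4 stands at a limit of the assay, not at a number: the limit of > 100000 nM in this assay, at which 1 of the 4 values shown sits.

The step reads an at least 1.7-fold higher number from compound 3 to compound 4 (0.24 log units; that floor lies within the scatter), so only a floor is available; that floor does not fix the size of the change, but nothing in it points to a stronger inhibitor of growth. Within the data shown here, this is the first reading at this place, on the aromatic carbon between two ring nitrogen atoms, for a ring with a hetero atom and a hydrogen-bond donor, and on the trifluoromethyl-bearing aryl background 1H-pyrrol-2-yl brings no measurable gain over cyclopentyl, whereas the earlier step of a 1.5-fold higher number from compound 1 to compound 2 (0.18 log units; within the scatter) covered only a carbon-only aromatic ring on the fluoro-bearing background.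

The compounds shown leave open whether the hetero atom or the donor hydrogen counts here, which furan-2-yl or 1-methylpyrrol-2-yl at this place could separate, and whether 1H-pyrrol-2-yl reads the same with fluoro on the other aryl group. Also open, from the compounds shown here alone, are an amine or a longer alkyl chain at this place, and a carboxylic acid in place of the methoxycarbonyl group.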